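From 2-methylphenyl to 2-fluorophenyl in a cytotoxicity read-out

This account rests on a few compounds, and the source may have more. Where it says the series, first, only, none or still open, it means among the compounds named here.

compound 1 `Cc1cnc(NC(=O)CSc2nncnc2-c2ccccc2Cl)c(Br)c1` gives 144000 nM
compound 2 `O=C(CSc1nncnc1-c1ccccc1Cl)Nc1ccccc1Br` gives 73000 nM
compound 3 `Cc1ccccc1NC(=O)CSc1nncnc1-c1ccccc1Cl` gives 142000 nM

In an ADME assay on MT4 cells (Homo sapiens) for cytotoxicity, read by MTT assay (on this read-out higher numbers stand for lower toxicity in this test and lower numbers for higher toxicity in this test), compound 3 gives 142000 nM and so lies within the scatter of both compound 1 and compound 2. Compound 4 `O=C(CSc1nncnc1-c1ccccc1Cl)Nc1ccccc1F` differs from it by fluoro in place of methyl on an aromatic carbon with fluoro in place of methyl on an aromatic carbon, ortho to a large group. The nearest measured exchange, methyl in place of bromo, gave a 1.9-fold higher number from compound 2 to compound 3 (0.29 log units; within the scatter) and the other two measured steps were a 1.0-fold lower number from compound 1 to compound 3 (0.01 log units; within the scatter) and a 2.0-fold lower number from compound 1 to compound 2 (0.30 log units; within the scatter) in the same read-out. None of these leaves the scatter, so no step beyond it is expected. The expected step is a 1.4-fold lower number from compound 3 to compound 4 (0.13 log units; within the scatter) by this estimate. Compound 4 is estimated at 105000 nM with an expected range of 50000 nM to 200000 nM in this read-out.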

Compound 4, half-maximal cytotoxic concentration: 98000 nM
Estimate against measurement, compound 4: 1.1-fold (0.03 log units) above, within the range that was stated.
By their numbers in this assay, from the lowest: compounds 2, 4, 3 and 1 (each within the scatter of the next).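

On the aromatic carbon ortho to a large group, fluoro now joins methyl and bromo in this assay: in place of methyl it gives a 1.4-fold lower number from compound 3 to compound 4 (0.16 log units; within the scatter), and in place of bromo it gives a 1.3-fold higher number from compound 2 to compound 4 (0.13 log units; within the scatter). Exchanging the whole 3-bromo-5-methylpyridin-2-yl for 2-fluorophenyl gives a 1.5-fold lower number from compound 1 to compound 4 (0.17 log units; within the scatter), so this exchange also stays within the scatter, as do all the other steps among these compounds. No supporting data are available to explain this result.

Going by these compounds, whether an amine or a carboxylic acid at this position would leave the scatter in this assay remains open.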